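The source may report more compounds than this note shows. Statements on the series, on what has been measured and on what is new or still open speak of the compounds shown alone.

In a physicochemical assay for solubility, with a stated time of 3 days, at pH 7 (on this read-out higher numbers stand for higher solubility and lower numbers for lower solubility), compound 1 `Cc1ccc(CN2CCCCC2CCOc2ccc(-c3nc4cc(C(N)=O)ccc4[nH]3)cc2)cc1` gives 97000 nM and compound 2 `COc1ccc(CN2CCCCC2CCOc2ccc(-c3nc4cc(C(N)=O)ccc4[nH]3)cc2)cc1` gives 84000 nM, so these two numbers sit within the usual scatter of each other. Compound 3 `NC(=O)c1ccc2[nH]c(-c3ccc(OCCC4CCCCN4Cc4ccc(Cl)c(Cl)c4)cc3)nc2c1` differs from compound 2 in one place: 3,4-dichlorophenyl in place of 4-methoxyphenyl on a saturated chain carbon bound to an amine nitrogen in a ring. The same difference can be read as 4-methoxybenzyl to 3,4-dichlorobenzyl. Among the compounds with values here, only one measured step bears on this change: a 1.2-fold lower number from compound 1 to compound 2 (0.06 log units; within the scatter), which puts methoxy in place of methyl on an aromatic carbon. Within the data shown here, it stays within the scatter, but it involves a different swap, and no measured compound carries chlorine, so it is only a weak guide. A real drop in this assay is still the expectation, though its size is uncertain. The estimated change is a 2.8-fold lower number from compound 2 to compound 3 (0.45 log units; beyond the scatter). For compound 3 the expected value is 30000 nM, with an estimated range from 6000 nM to 90000 nM.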

Compound 3, solubility: 229000 nM
For compound 3 the middle estimate is 7.6-fold (0.88 log units) below the measured one; measured number outside the range, above it.
By their numbers in this assay, from the lowest: compounds 2 and 1 (each within the scatter of the next); then compound 3.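

In this assay, the aromatic group on a saturated chain carbon bound to an amine nitrogen in a ring now proves able to move the number beyond the scatter: 3,4-dichlorophenyl in place of 4-methoxyphenyl gives a 2.7-fold higher number from compound 2 to compound 3 (0.44 log units; beyond the scatter), and 3,4-dichlorophenyl in place of 4-methylphenyl gives a 2.4-fold higher number from compound 1 to compound 3 (0.37 log units; beyond the scatter). Within the data shown here, the only earlier step, methoxy in place of methyl, stayed within the scatter, so compound 1 and compound 2 alone gave no sign that a change to this group could shift the number, let alone upward. Nothing available here accounts for this rise.

Whether the two chlorines are both needed stays open, since the shown compounds leave it unknown how a 4-chlorophenyl group would compare with compound 3. How a ring carrying an amine or a carboxylic acid at this place would read is open as well.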